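Pyridinyl isomers in a dimethoxyphenyl pyrazoline series

This account rests on a few compounds, and the source may have more. Where it says the series, first, only, none or still open, it means among the compounds named here.

Measured compounds:
compound 1, `COc1ccc(OC)c(-c2nc(-c3ccccn3)no2)c1`, 28%
compound 2, `COc1ccc(OC)c(C2CC(c3ccccn3)=NN2c2ccccc2)c1`, 27%
compound 3, `COc1ccc(OC)c(C2CC(c3ccccn3)=NN2)c1`, 15%

In a functional assay on the whole organism (strain Charles Foster albino) for inhibition, with Rattus norvegicus as the target, read by paw edema, with stated times of 30 min and 3 h, at a dose of 50 mg/kg by the oral route (on this read-out higher numbers stand for more inhibition at the one dose given (going by the name of the read-out) and lower numbers for less inhibition), compound 2 stands second highest of the three numbers. Its nearest neighbour is compound 1, whose value lies within the scatter of that of compound 2. Compound 3 is furthest away, lower by a number 12 percentage points lower from compound 2 to compound 3 (beyond the scatter).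

Compound 4, `COc1ccc(OC)c(C2CC(c3cccnc3)=NN2c2ccccc2)c1`, differs from compound 2 in one place: pyridin-3-yl in place of pyridin-2-yl on a carbon with a double bond to nitrogen. Among the measured compounds shown here, no measured step touches this kind of change; the only step on record, a number 12 percentage points lower from compound 2 to compound 3 (beyond the scatter), concerns the amine nitrogen in the ring and so does not inform it. With nothing to point either way, the expected step from compound 2 is no change at the digits printed from compound 2 to compound 4 (within the scatter), that is, none beyond the scatter. Compound 4 is therefore estimated at 27%, between 12% and 42%.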

Compound 4, a percentage reported as inhibition, in the whole organism at one dose (the size of the read-out at that dose, not a potency): 24%
Compound 4: the middle estimate sits 3 percentage points above what was measured; the measured number falls inside the stated range.
By their numbers in this assay, from the lowest: compounds 3, 4, 2 and 1 (each within the scatter of the next, the first and the last beyond it).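

In this assay, pyridin-3-yl in place of pyridin-2-yl on the carbon with a double bond to nitrogen gives a number 3 percentage points lower from compound 2 to compound 4 (within the scatter) at the one dose, so this position accepts the second pyridine isomer without a change beyond the scatter. The earlier compounds shown here all carried pyridin-2-yl and said nothing on this point. No measurement on hand explains this result.

From the compounds shown here alone, whether pyridin-4-yl or a phenyl bearing a carboxylic acid would read differently at this carbon stays open. Also open, going by these compounds, is whether pyridin-3-yl gives the same reading with hydrogen in place of phenyl on the ring nitrogen.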